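The source may report more compounds than this note shows. Statements on the series, on what has been measured and on what is new or still open speak of the compounds shown alone.

Working notes on the series. Compound 2 `COc1nc(N)nc2c1c(-c1ccccc1)cn2[C@@H]1O[C@H](CO)[C@@H](O)[C@H]1O` stands at the ceiling of an ADME assay on BJ cells (Homo sapiens), read by MTT assay, with a stated time of 72 h (a lower number here means a stronger inhibitor, a higher number a weaker inhibitor), where compound 2 gives > 100000 nM, a limit rather than a number. Compound 3 `COc1ncnc2c1c(-c1ccccc1)cn2[C@@H]1O[C@H](CO)[C@@H](O)[C@H]1O` likewise returns only a limit, > 100000 nM. Compound 1 `Nc1nc(N)c2c(-c3ccoc3)cn([C@@H]3O[C@H](CO)[C@@H](O)[C@H]3O)c2n1` also returns only a limit, > 100000 nM. Among the compounds with values here, the one step joining two of these, a step that the two limits leave unreadable from compound 2 to compound 3, cannot be read because of the limit of > 100000 nM in this assay, at which 3 of the 3 values shown sit. Compound 4 `COc1nc(N)nc2c1c(-c1ccoc1)cn2[C@@H]1O[C@H](CO)[C@@H](O)[C@H]1O` differs from compound 2 by furan-3-yl in place of phenyl on an aromatic carbon. Within the data shown here, no measured step tests this change, and the single step available is unreadable, so the expectation rests solely on every value so far being a limit. Compound 4 is accordingly expected near 150000 nM, ranging from 30000 nM to 1000000 nM. The expected step is then a step that the limit leaves unreadable from compound 2 to compound 4, a guess that a further limit would leave unconfirmed.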

Compound 4, half-maximal inhibitory concentration: > 100000 nM
Compound 4 was reported as a limit; the forecaster's own chance of this, stated with the estimate: 85%; the middle value does not contradict the limit.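

Neither the step from compound 2 to compound 4 nor the step from compound 1 to compound 4 can be read, because both ends of each are limits: the limit of > 100000 nM in this assay, at which 4 of the 4 values shown sit.

The compounds shown leave open whether any of these changes shifts the read-out in this assay.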